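Adding a Third Methoxy Group to Compound 2

The source may hold more compounds than are shown below. What is called first, only, known or untested is meant among the compounds shown, and "the series" means these compounds.

Two compounds have so far been measured in an ADME assay on HaCaT cells (Homo sapiens) for inhibition, read by sulforhodamine B assay, with a stated time of 48 h; on this read-out lower numbers stand for stronger inhibition of growth and higher numbers for weaker inhibition of growth:
Compound 1, `COc1ccc(/C=C/C2CC(=O)C=CO2)cc1`, gives 145 uM.
Compound 2, `COc1ccc(/C=C/C2CC(=O)C=CO2)cc1OC`, gives 134 uM.

Compound 2 stands at the lowest of these two numbers, though the gap to compound 1 is small: a 1.1-fold lower number from compound 1 to compound 2 (0.03 log units; within the scatter), a step inside the usual scatter of this kind of measurement. Compound 3, `COc1cc(/C=C/C2CC(=O)C=CO2)cc(OC)c1OC`, has not yet been measured. It differs from compound 2 by methoxy in place of hydrogen on an aromatic carbon. Among the compounds with values here, the only step seen so far is of the same kind, a methoxy in place of hydrogen on an aromatic carbon, and it moved the number only within the scatter. On that basis, adding one more methoxy is expected to bring no step beyond the scatter in this assay, and the expected step is a 1.0-fold lower number from compound 2 to compound 3 (0.01 log units; within the scatter). Compound 3 is therefore estimated to give 130 uM in this assay, most likely between 70 uM and 250 uM.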

Compound 3, concentration for growth inhibition (reported as GI): 155 uM
Beside the measured number, compound 3's estimate is 1.2-fold (0.08 log units) below it, and the stated range covers the measured number.
By their numbers in this assay, from the lowest: compounds 2, 1 and 3 (each within the scatter of the next).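

In this assay, a methoxy placed on an aromatic carbon ortho to a methoxy group and meta to a group of 9 heavy atoms gives a 1.2-fold higher number from compound 2 to compound 3 (0.06 log units; within the scatter) and so stays within the scatter, even though this ring already carries methoxy groups. This second step joins a 1.1-fold lower number from compound 1 to compound 2 (0.03 log units; within the scatter) as another replacement of hydrogen by methoxy that stays within the scatter, and none of the three compounds goes against that pattern. No information is available here on what lies behind these small steps.

Going by these compounds, whether an amine, a carboxylic acid or a longer chain at this position would move the number beyond the scatter remains open. Also open, on these data alone, is whether a change to the shared core, away from the aromatic ring, would do so.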